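Taking the Pyridine Ester Away: Expected Loss of Inhibition

The compounds below may be only part of what the source reports. "The series", "measured", "known", "first", "only" and "open" are said of these compounds alone.

Measured so far in a functional assay on the whole organism with Rattus norvegicus as the target, with a stated time of 4 h, at a dose of 40 mg/kg by the intraperitoneal route; a higher number here means more inhibition at the dose given (going by the name of the read-out), a lower number less inhibition:
compound 1 `CCSCc1c(C)nc2c(OCc3ccccc3)cccn12`: 36%
compound 2 `Cc1nc2c(OCc3ccccc3)cccn2c1COC(=O)c1cccnc1`: 87%

Compound 2 stands highest of the two numbers, and the nearest number belongs to compound 1. Among the compounds with values here, the only measured step is a number 51 percentage points higher from compound 1 to compound 2 (beyond the scatter), a large change brought about by putting the pyridinylcarbonyloxy group in place of ethylsulfanyl on the saturated chain carbon bound to an aromatic carbon.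

Compound 3 `Cc1nc2c(OCc3ccccc3)cccn2c1C` has not yet been measured. Its difference from compound 2 is hydrogen in place of ((pyridin-3-yl)carbonyl)oxy on a saturated chain carbon bound to an aromatic carbon. The group whose arrival accompanied the large rise to compound 2 is now removed, with hydrogen left behind. That measured step bears on the change, though compound 3 carries no ethylsulfanyl either, so the match is not exact. A fall beyond the scatter is expected in this assay, roughly back toward the region of compound 1. Compound 3 is expected to give about 40%. The expected range for compound 3 runs from 15% to 65%. That expectation amounts to a number 47 percentage points lower from compound 2 to compound 3 (beyond the scatter).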

Compound 3, a percentage reported as inhibition, in the whole organism at one dose (the size of the read-out at that dose, not a potency): 99%
Estimate against measurement, compound 3: 59 percentage points below; the measured number lies above the stated range.
By their numbers in this assay, from the lowest: compound 1; then compound 2; then compound 3.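

In this assay the ester is not needed for a high number at this saturated chain carbon: with hydrogen in place of ((pyridin-3-yl)carbonyl)oxy, the result is a number 12 percentage points higher from compound 2 to compound 3 (beyond the scatter) and not a fall. The rise seen with the ester therefore no longer reads as a gain from that group, since hydrogen in place of ethylsulfanyl gives a number 63 percentage points higher from compound 1 to compound 3 (beyond the scatter) and the simplest compound, compound 3, stands highest of the three. Nothing available explains why the three compounds fall in this order.

Within the data shown here, only two groups can be set against hydrogen at this carbon, so it remains open whether a hydroxyl or an amine there would stay near compound 3 or drop toward compound 1. Going by these compounds, each number also comes from a single dose, so how the compounds compare at lower doses remains open too.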